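Sulfone series: expected stability of compound 3

This account rests on a few compounds, and the source may have more. Where it says the series, first, only, none or still open, it means among the compounds named here.

In an ADME assay on microsomes from liver (Homo sapiens) for metabolic stability, tested at 2.5 uM (a higher number here means faster removal of the compound, a lower number slower removal), compound 1 `O=S(=O)(c1ccc(F)c(Cl)c1)c1cnc2c(F)cccc2c1-c1ccc(F)cc1` gives 0.19 mL/min and compound 2 `O=S(=O)(c1ccc(F)c(F)c1)c1cnc2c(F)cccc2c1-c1ccc(F)cc1` gives 0.78 mL/min; the step of a 4.1-fold higher number from compound 1 to compound 2 (0.61 log units; beyond the scatter) is the only one measured. Compound 2 thus stands highest of the two numbers. Compound 3 `COc1ccc(-c2c(S(=O)(=O)c3ccc(F)c(F)c3)cnc3c(F)cccc23)cc1` differs from compound 2 by methoxy in place of fluoro on an aromatic carbon. Among the compounds with values here, no measured step covers a methoxy entering for a fluoro, so the change has no direct precedent here, and the one measured step was modest. For compound 3 a step of a 1.5-fold higher number from compound 2 to compound 3 (0.19 log units; within the scatter) is expected, with an estimate of 1.2 mL/min and a range from 0.5 mL/min to 3 mL/min in this assay.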

Compound 3, intrinsic clearance in a liver preparation (reported as CLH), per the amount of preparation that the assay uses: 2.12 mL/min
Compound 3: middle estimate off by 1.8-fold (0.25 log units), on the low side, within the range that was stated.
By their numbers in this assay, from the lowest: compound 1; then compound 2; then compound 3.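

In this assay, the change from 4-fluorophenyl to 4-methoxyphenyl gives a 2.7-fold higher number from compound 2 to compound 3 (0.43 log units; beyond the scatter) and so shows that this place, para to a large group, also affects the read-out. The earlier step covered only fluoro in place of chloro at another place, so the series now has two places where a single change moves the number beyond the scatter. Nothing available explains the rise.

The compounds shown leave open how an amine or an ethoxy at this place would read. They also leave open whether methoxy in place of fluoro gives a similar step with the chloro present in compound 1.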